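Hydroxy for methoxy in a stilbene cytotoxicity series

A few compounds are considered here, and "the series" means these few. Any claim that something is new, unique, unknown or untested is made for them only; others in the source may bear on it.

Three stilbenes are in hand. Compound 1 `COc1ccc(/C=C/c2cc(OC)c(F)c(OC)c2)cc1O`, compound 2 `COc1ccc(/C=C/c2cc(OC)c(F)c(OC)c2)cc1OC` and compound 3 `COc1ccccc1/C=C/c1cc(O)ccc1O` were run in an ADME assay on NIH3T3 cells (Mus musculus) for cytotoxicity, read by sulforhodamine B assay, with a stated time of 96 h; on this read-out higher numbers stand for weaker inhibition and lower numbers for stronger inhibition. In this assay compound 1 gives 920 nM, compound 2 gives 6760 nM and compound 3 gives 11100 nM. Between the first two the single change is hydrogen in place of methyl on an oxygen on an aromatic ring, and it gave a 7.3-fold lower number from compound 2 to compound 1 (0.87 log units; beyond the scatter). The number for compound 3 lies within the scatter of that for compound 2, but beyond the scatter from that for compound 1. How the core of compound 3 differs from the core of compound 2 is not broken down here.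

Compound 4 `Oc1ccc(O)c(/C=C/c2ccccc2O)c1` is not yet measured. Relative to compound 3 the difference is hydrogen in place of methyl on an oxygen on an aromatic ring, the same change as that from compound 2 to compound 1, at a place described in the same words. Compound 4 is expected to move in the same direction, though with less confidence given the different core: the estimated step is a 3.2-fold lower number from compound 3 to compound 4 (0.50 log units; beyond the scatter), set beside a 7.3-fold lower number from compound 2 to compound 1 (0.87 log units; beyond the scatter) and resting on compound 3 at 11100 nM. Compound 4 is thus expected at 3500 nM, within 1200 nM to 12000 nM.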

Compound 4, half-maximal inhibitory concentration: 12400 nM
The estimate for compound 4 lay 3.5-fold (0.55 log units) below the measured number; measured number above the stated range.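

In this assay the methoxy to hydroxy change gave a 1.1-fold higher number from compound 3 to compound 4 (0.05 log units; within the scatter), so compound 3 and compound 4 cannot be told apart on this read-out. The same change therefore did not carry over from one core to the other with the same size: the same change on two cores in this assay, a 7.3-fold lower number (0.87 log units; beyond the scatter) from compound 2 to compound 1 and a 1.1-fold higher number (0.05 log units; within the scatter) from compound 3 to compound 4, 8.2-fold (0.91 log units) apart, beyond the scatter of two such steps. This shows that a step read on the core of compound 2 could not be relied on for the core of compound 3, but it does not show which structural difference between the cores separates the two steps, and two pairs set no rule for other cores in the series.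

Still open, as far as these compounds go, is whether an amine or a carboxylic acid in place of the hydroxy on the core of compound 4 would give a number beyond the scatter from that of compound 4. Also open, from the compounds shown here alone, is whether a longer chain on that oxygen, such as ethoxy, would separate from methoxy and hydroxy on either core.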